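Replacing the (3,5-dichlorophenyl)carbamoyl group of compound 3

The source may report more compounds than this note shows. Statements on the series, on what has been measured and on what is new or still open speak of the compounds shown alone.

In a functional assay on KBVIN cells (Homo sapiens) for antiproliferative activity, read by sulforhodamine B assay, with a stated time of 3 days (a lower number here means a stronger inhibitor of growth, a higher number a weaker inhibitor of growth), compound 3 (`O=C(Nc1cc(Cl)cc(Cl)c1)c1cccc(Nc2ncc(F)c(Nc3ccc(F)cc3)n2)c1`) gives 20700 nM as its measured value. Compound 2 (`CN1CCC(C(=O)Nc2cccc(Nc3ncc(F)c(Nc4ccc(F)cc4)n3)c2)CC1`) gives 11900 nM as its value, and a 1.7-fold higher number from compound 2 to compound 3 (0.24 log units; within the scatter) leaves the two level. Compound 1 (`O=C(Nc1nccs1)c1cccc(Nc2ncc(F)c(Nc3ccc(F)cc3)n2)c1`) is recorded only as a limit, > 10000 nM in its case. Neither a step that the limit leaves unreadable from compound 1 to compound 2 nor a step that the limit leaves unreadable from compound 1 to compound 3 can therefore guide a prediction.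

Compound 4 (`CN(C)CC(=O)Nc1cccc(Nc2ncc(F)c(Nc3ccc(F)cc3)n2)c1`) keeps the shared core but carries (((dimethylamino)methyl)carbonyl)amino in place of (3,5-dichlorophenyl)carbamoyl on an aromatic carbon. The closest measured comparison is compound 2, which has ((1-methylpiperidin-4-yl)carbonyl)amino on that carbon and gives 11900 nM as its value. Among the compounds with values here, the only readable step, a 1.7-fold higher number from compound 2 to compound 3 (0.24 log units; within the scatter), stays within the scatter, so no step beyond the scatter is expected in this assay. The expected change is a 1.7-fold lower number from compound 3 to compound 4 (0.24 log units; within the scatter) on this estimate. For compound 4 the estimated value is 12000 nM with an expected range from 5000 nM to 30000 nM in this assay.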

Compound 4, concentration for 50% growth inhibition: 1810 nM
Beside the measured number, compound 4's estimate is 6.6-fold (0.82 log units) above it; the whole stated range lies above it.
By their numbers in this assay, from the lowest: compound 4; then compounds 2 and 3 (each within the scatter of the next).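

In this assay, within the data shown here, this position on the aromatic carbon proves able to shift the number well beyond the scatter, with an 11-fold lower number from compound 3 to compound 4 (1.06 log units; beyond the scatter), whereas the one readable step among the earlier compounds stayed within it. The change at the carbonyl carbon alone also matters, since (dimethylamino)methyl in place of 1-methylpiperidin-4-yl gives a 6.6-fold lower number from compound 2 to compound 4 (0.82 log units; beyond the scatter), so the open-chain group and the ring-bearing group are not interchangeable here. The comparison with the thiazolyl amide gives an at least 5.5-fold lower number from compound 1 to compound 4 (0.74 log units; beyond the scatter), and its size rests on a limit: the limit of > 10000 nM in this assay, at which 1 of the 4 values shown sits.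

Going by these compounds, it remains open whether the dimethylamino nitrogen itself is needed, as a plain isopropyl group in its place would test. Also open, on these data alone, is how a longer chain before the amine, or a pyrrolidine or morpholine in place of the dimethylamino group, would read.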